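The source may report more compounds than this note shows. Statements on the series, on what has been measured and on what is new or still open speak of the compounds shown alone.

Compound 1 `CCOC(=O)[C@@H](N)CCC(=O)NCCSC(C)=O` gives 1730000 nM in an ADME assay on HaCaT cells (Homo sapiens) for cytotoxicity, read by MTT assay, with a stated time of 48 h (a lower number here means that less compound is needed, a higher number that more compound is needed for the effect), the highest of the two numbers recorded; compound 2 `CCCOC(=O)[C@@H](N)CCC(=O)NCCSC(=O)C(C)(C)C` gives 152000 nM in this assay, a lower number beyond the scatter. Compound 3 `CCOC(=O)[C@@H](N)CCC(=O)NCCSC(=O)c1ccccc1` has not yet been measured in this assay; it differs from compound 1 by phenyl in place of methyl on a carbonyl carbon. Among the measured compounds shown here, no step between measured compounds is available to guide the change, so only a modest move toward a lower number is expected, larger than the scatter but not by much. For compound 3 the estimated step is a 3.5-fold lower number from compound 1 to compound 3 (0.54 log units; beyond the scatter). Compound 3 is therefore expected to give 500000 nM in this assay, within a range from 150000 nM to 1700000 nM.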

Compound 3, half-maximal effective concentration in the HaCaT assay: 331000 nM
Compound 3: the middle estimate sits 1.5-fold (0.18 log units) above what was measured; the range from low to high includes it.
By their numbers in the HaCaT assay, from the lowest: compound 2; then compound 3; then compound 1.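

In the HaCaT assay, phenyl in place of methyl on a carbonyl carbon whose other neighbour is sulfur gives a 5.2-fold lower number from compound 1 to compound 3 (0.72 log units; beyond the scatter); this isolates the effect of one place, which compound 1 and compound 2 could not do, as they differ in more than one. In a physicochemical assay for lipophilicity, at pH 7.4 (a lower number here means a more polar compound, a higher number a more lipophilic compound), compound 1 gives -1.44 and compound 3 gives -0.37, so both read-outs rise or fall with this change, though a single pair establishes no link between them. Going by these compounds, whether the aromatic ring or simply the added carbon accounts for the step stays open, as does how a cyclohexyl group or a longer chain would read on this carbonyl carbon.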